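Three Ring Fluorines in Place of a Trifluoromethyl Group

This account rests on a few compounds, and the source may have more. Where it says the series, first, only, none or still open, it means among the compounds named here.

Compound 3 `COc1cc(C(=O)c2cc(OC)c(OC)c(OC)c2)cc(NC(=O)/C=C/c2ccc(C(F)(F)F)cc2)c1OC` gives 3000 nM in a functional assay on HeLa cells (Homo sapiens) for cytotoxicity, read by MTT assay, with a stated time of 72 h (on this read-out lower numbers stand for stronger inhibition and higher numbers for weaker inhibition), the lowest of the three numbers recorded so far. Compound 1 `COc1ccc(/C=C/C(=O)Nc2cc(C(=O)c3cc(OC)c(OC)c(OC)c3)cc(OC)c2OC)cc1` gives 11200 nM in this assay, and compound 2 `COc1cccc(/C=C/C(=O)Nc2cc(C(=O)c3cc(OC)c(OC)c(OC)c3)cc(OC)c2OC)c1` gives 6900 nM in this assay. The two steps that lead to compound 3 are a 3.7-fold lower number from compound 1 to compound 3 (0.57 log units; beyond the scatter) and a 2.3-fold lower number from compound 2 to compound 3 (0.36 log units; beyond the scatter), both modest, while the step of a 1.6-fold lower number from compound 1 to compound 2 (0.21 log units; within the scatter) stays within the scatter.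

Compound 4 `COc1cc(C(=O)c2cc(OC)c(OC)c(OC)c2)cc(NC(=O)/C=C/c2cc(F)c(F)c(F)c2)c1OC` differs from compound 3 by 3,4,5-trifluorophenyl in place of 4-(trifluoromethyl)phenyl on a double-bonded chain carbon bound to a double-bonded chain carbon. Among the compounds with values here, no measured pair mirrors this change directly. The two steps that do bear on this part of the molecule, both replacing a methoxy-bearing ring with the trifluoromethyl-bearing one, moved the number only modestly, and the fluorine-bearing ring of compound 4 is not matched by any recorded step. Compound 4 is therefore expected to show a 1.2-fold higher number from compound 3 to compound 4 (0.07 log units; within the scatter) in this assay, a step that may not reach beyond the scatter. The estimate for compound 4 in this assay is 3500 nM, with a range from 1200 nM to 10000 nM.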

Compound 4, half-maximal inhibitory concentration: 5000 nM
For compound 4 the middle estimate is 1.4-fold (0.15 log units) below the measured one, within the range that was stated.
By their numbers in this assay, from the lowest: compounds 3, 4, 2 and 1 (each within the scatter of the next, the first and the last beyond it).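

In this assay, the step of a 1.7-fold higher number from compound 3 to compound 4 (0.22 log units; within the scatter) stays within the scatter, so at this place, on a double-bonded chain carbon bound to a double-bonded chain carbon, 3,4,5-trifluorophenyl and 4-(trifluoromethyl)phenyl cannot be told apart. Against the two methoxy-bearing rings the new ring gives a divided result: a 1.4-fold lower number from compound 2 to compound 4 (0.14 log units; within the scatter) is also within the scatter, whereas a 2.2-fold lower number from compound 1 to compound 4 (0.35 log units; beyond the scatter) goes modestly beyond it, so compound 4 is separated only from the 4-methoxyphenyl compound. Nothing available explains any of these steps.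

The compounds shown leave open how this position responds to a ring carrying an amine, a carboxylic acid or a nitrile. They also leave open whether a plain phenyl ring would stand with the fluorine-bearing rings or with the methoxy-bearing ones.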